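Trading a fluorinated ring for a plain chain

The compounds below may be only part of what the source reports. "The series", "measured", "known", "first", "only" and "open" are said of these compounds alone.

Of the compounds shown here, three sharing one core have been measured in an assay on a protein complex for inhibition of NEDD8 activating enzyme (Homo sapiens), read by HTRF, with a stated time of 2 h, in the presence of a further agent that is not named here; a lower number here means a stronger inhibitor, a higher number a weaker inhibitor. Compound 1, with the structure `NS(=O)(=O)OC[C@@H]1C[C@@H](n2ncc3c(N[C@H]4CCc5ccccc54)ccnc32)C[C@@H]1O`, gives only a limit there: > 10000 nM. Going by the values given here, that limit is what the limit of > 10000 nM in this assay, at which 1 of the 3 values shown sits, describes; it says only that a number was not reached. Compound 2, with the structure `NS(=O)(=O)OC[C@@H]1C[C@@H](Nc2ncnc(N[C@H]3CCc4ccccc43)c2F)C[C@@H]1O`, gives 219 nM in this assay. Compound 3, with the structure `NS(=O)(=O)OC[C@@H]1C[C@@H](n2nnc3c(NCc4ccccc4F)ncnc32)C[C@@H]1O`, gives 6.11 nM in this assay, the lowest of the two numbers that exist, and its gap to compound 2 lies beyond the usual scatter.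

Compound 4, with the structure `CCCCCCNc1ncnc2c1nnn2[C@@H]1C[C@@H](COS(N)(=O)=O)[C@@H](O)C1`, has not been measured. It differs from compound 3 in one place: pentyl in place of 2-fluorophenyl on a saturated chain carbon bound to a nitrogen on an aromatic ring. Put more simply, a 2-fluorobenzyl group on the amine becomes a hexyl chain, so a flat aromatic ring gives way to a flexible saturated chain.

Among the compounds with values here, no two measured compounds here differ in this single way, so no measured step speaks directly to it. The expectation for the step from compound 3 to compound 4 in this assay is a clear move toward weaker inhibition, a 7.4-fold higher number from compound 3 to compound 4 (0.87 log units; beyond the scatter). Compound 4 is therefore estimated at 45 nM in this assay, within a range from 8 nM to 250 nM.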

Compound 4, half-maximal inhibitory concentration: 21.1 nM
Estimate against measurement, compound 4: 2.1-fold (0.33 log units) above, and the stated range covers the measured number.
By their numbers in this assay, from the lowest: compound 3; then compound 4; then compound 2. At a limit, above all of these: compound 1.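

The group on this amine does not need an aromatic ring for inhibition to hold up largely intact: in this assay, replacing the 2-fluorobenzyl group with a hexyl chain gives a 3.5-fold higher number from compound 3 to compound 4 (0.54 log units; beyond the scatter), a modest change, although one beyond the usual scatter. Going by these compounds alone, the earlier compounds could not show this, since no two of them differed in one place only, and this pair gives the first direct reading of what this substituent contributes. Nothing measured among these compounds explains the size of the step.

This single change removes the ring and the fluorine together, so their separate contributions cannot be told apart, and a plain benzyl group would be needed to show whether the fluorine matters on its own. Going by these compounds, it also remains open what a shorter butyl chain, a longer octyl chain, or a hexyl chain ending in an amine or a carboxylic acid would give on this same nitrogen, and so how far the tolerance seen here extends.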